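A few compounds are considered here, and "the series" means these few. Any claim that something is new, unique, unknown or untested is made for them only; others in the source may bear on it.

Compound 1 `Cc1ccccc1S(=O)(=O)c1ccc(CNC(=O)c2cc3cnccc3[nH]2)cc1`: 13 nM
Compound 2 `O=C(NCc1ccc(S(=O)(=O)c2ccccc2)cc1)c1cc(-c2cccnc2)no1`: > 10000 nM (a limit)
Compound 3 `O=C(NCc1ccc(S(=O)(=O)c2ccccc2)cc1)c1c[nH]c2ccncc12`: 2100 nM

In a functional assay on A2780 cells (Homo sapiens) for inhibition, read by sulforhodamine B assay, with a stated time of 72 h (a lower number here means a stronger inhibitor, a higher number a weaker inhibitor), compound 1 gives 13 nM, the lower of the two actual numbers in the series. Compound 3, at 2100 nM, lies far from it, beyond the scatter. The reading for compound 2 of > 10000 nM is a limit of the assay and not a number.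

Compound 4 `O=C(NCc1ccc(S(=O)(=O)c2ccc(F)cc2)cc1)c1cc2cnccc2[nH]1` keeps the core of compound 1 and carries 4-fluorophenyl in place of 2-methylphenyl on a sulfonyl sulfur.

For the measured compounds named here, no measured pair isolates this change. Compounds 2 and 3 differ from compound 1 in more than one place, so they give no measure of it. The expectation in this assay therefore starts from compound 1 at 13 nM, with no step beyond the scatter and neither direction favoured. The expected size is a 1.1-fold lower number from compound 1 to compound 4 (0.03 log units; within the scatter). For compound 4 the estimated value is 12 nM, with an expected range of 3 nM to 50 nM.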

Compound 4, half-maximal inhibitory concentration: 16 nM
Compound 4: the middle estimate sits 1.3-fold (0.12 log units) below what was measured, within the range that was stated.
By their numbers in this assay, from the lowest: compounds 1 and 4 (each within the scatter of the next); then compound 3. At a limit, above all of these: compound 2.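

In this assay, 4-fluorophenyl in place of 2-methylphenyl on a sulfonyl sulfur gives a 1.2-fold higher number from compound 1 to compound 4 (0.09 log units; within the scatter). For the compounds shown here, this is the only single-place comparison so far, and it shows that on the core of compound 1 the two aryl groups cannot be told apart in this assay, so a methyl group on the phenyl ring is not required for a value in this range. No measurement shown here bears on why the step is this small.

Open, on these data alone, is whether this position keeps such values with a group other than a substituted phenyl ring, such as a cyclohexyl ring or a morpholine. Also open, as far as these compounds go, is how a methoxy or chloro group on the phenyl ring would read on the same core.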